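Benzamido to cyano: expected effect on cytotoxicity

The source may report more compounds than this note shows. Statements on the series, on what has been measured and on what is new or still open speak of the compounds shown alone.

Compound 1 `COc1ccc(/C=C\C(=O)O)c(OCc2cn(-c3ccc(NC(=O)c4ccccc4)cc3)nn2)c1CC=C(C)C` gives 17200 nM in a functional assay on NCI-H322 cells (Homo sapiens) for cytotoxicity, read by MTT assay, with a stated time of 24 h; a higher number here means a weaker inhibitor, a lower number a stronger inhibitor. Compound 2 `COc1ccc(/C=C\C(=O)O)c(OCc2cn(-c3cccc(C#N)c3)nn2)c1CC=C(C)C` gives 26500 nM in this assay, and the two numbers sit within the scatter of each other, so compound 1 does not stand apart from compound 2. Compound 3 `COc1ccc(/C=C\C(=O)O)c(OCc2cn(-c3ccc(C#N)cc3)nn2)c1CC=C(C)C` is not yet measured; it differs from compound 1 by cyano in place of benzamido on an aromatic carbon. Within the data shown here, no measured pair shares exactly this change, so from compound 1 to compound 3 a step of a 1.3-fold higher number from compound 1 to compound 3 (0.11 log units; within the scatter) is expected, none beyond the scatter. The estimate for compound 3 in this assay is 22000 nM, with a range of 9000 nM to 55000 nM.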

Compound 3, half-maximal inhibitory concentration: 18600 nM
Beside the measured number, compound 3's estimate is 1.2-fold (0.07 log units) above it, and the stated range covers the measured number.
By their numbers in this assay, from the lowest: compounds 1, 3 and 2 (each within the scatter of the next).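

Exchanging benzamido for cyano on an aromatic carbon, para to a large group, gives a 1.1-fold higher number from compound 1 to compound 3 (0.03 log units; within the scatter) in this assay, so the benzamido group is not needed to hold the number at this level. Exchanging 3-cyanophenyl for 4-cyanophenyl on an aromatic nitrogen gives a 1.4-fold lower number from compound 2 to compound 3 (0.15 log units; within the scatter), so these two cyano compounds are not told apart. As far as these compounds go, whether an amine or a carboxylic acid on this aromatic carbon would give a step beyond the scatter remains open. No measurement at hand explains these steps.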